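Removing a chloro group from a weak soluble guanylate cyclase activator

A few compounds are considered here, and "the series" means these few. Any claim that something is new, unique, unknown or untested is made for them only; others in the source may bear on it.

Of the compounds shown here, two have been measured in an assay on CHO cells for activation of soluble guanylate cyclase alpha1/beta1 complex (Homo sapiens), read by cGMP accumulation; a lower number here means that less compound is needed, a higher number that more compound is needed for the effect. Compound 1 `COC(=O)N(C)c1c(N)nc(-n2nc(Cc3ccccc3F)c3ccccc32)nc1N` gives 310 nM in this assay. Compound 2 `CC1(C)C(=O)Nc2nc(-n3nc(Cc4ccccc4F)c4cc(Cl)ccc43)nc(N)c21` gives 18000 nM in this assay, the higher of the two numbers, and the gap between compound 1 and compound 2 lies well beyond the usual scatter. The two structures differ in more than one place, so no single change can be tied to that gap; the two values simply show that compound 2 needs far more material for the same effect.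

Compound 3 `CC1(C)C(=O)Nc2nc(-n3nc(Cc4ccccc4F)c4ccccc43)nc(N)c21` differs from compound 2 in one place only: hydrogen in place of chloro on an aromatic carbon. Within the data shown here, no measured pair shows the effect of this change on its own. Among the measured compounds shown here, with the only comparison being compound 1, which also lacks the chloro group but differs elsewhere, the step from compound 2 to compound 3 in this assay is expected to be modest and downward, about a 2.0-fold lower number from compound 2 to compound 3 (0.30 log units; within the scatter), within or near the scatter. Compound 3 is therefore estimated at 9000 nM, with a likely range from 2500 nM to 30000 nM.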

Compound 3, half-maximal effective concentration: 3000 nM
Compound 3: the middle estimate sits 3.0-fold (0.48 log units) above what was measured, within the range that was stated.
By their numbers in this assay, from the lowest: compound 1; then compound 3; then compound 2.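

In this assay, replacing the chloro group on the aromatic carbon with hydrogen gives a 6.0-fold lower number from compound 2 to compound 3 (0.78 log units; beyond the scatter), a step beyond the usual scatter. Among these compounds, this is the first direct reading of this position, since the two structures differ in that one place only and the whole shift can be tied to this single swap. On the core shared by these two compounds, the version with chloro needs clearly more material for the same effect than the version with hydrogen, so this carbon is a place where a single added atom changes the result; nothing measured here says why that happens.

On these data alone, the pair compares only two substituents at this carbon, so it remains open whether a fluoro, a methyl, a methoxy or an amine there would give a number closer to that of hydrogen, closer to that of chloro, or outside both. It also rests on one core alone, which leaves open whether adding chloro at the matching carbon of the core of compound 1 would shift the number in the same direction and by a similar amount.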